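From Dichlorophenyl to Dimethoxyphenyl in a Cell Growth Assay

The source may hold more compounds than are shown below. What is called first, only, known or untested is meant among the compounds shown, and "the series" means these compounds.

Going by the values given here, the three compounds measured so far were tested in a functional assay on M14 cells (Homo sapiens) for inhibition, read by sulforhodamine B assay, with a stated time of 48 h; a higher number here means that more compound is tolerated, a lower number that less compound is tolerated. Compound 1, `Nc1cc(N)c2nc(-c3ccccc3)c(Oc3ccc(Cl)c(Cl)c3)nc2c1`, gives only a limit in this assay, < 100000 nM. Compound 2, `CCOC(=O)[C@H](CCC(=O)O)NC(=O)c1ccc(CNc2nc3cc(N)cc(N)c3nc2-c2ccccc2)cc1`, likewise gives only a limit in this assay, < 100000 nM. Among the compounds with values here, compound 3, `Nc1cc(N)c2nc(-c3ccccc3)c(NCc3ccc(Cl)c(Cl)c3)nc2c1`, is the one compound with a number: in this assay compound 3 gives 75900 nM. Among the values shown, compound 3 therefore stands as the only number, with the two others sitting at a limit, which is what the limit of < 100000 nM in this assay, at which 2 of the 3 values shown sit, records.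

Compound 4, `COc1ccc(CNc2nc3cc(N)cc(N)c3nc2-c2ccccc2)cc1OC`, differs from compound 3 in a single place: 3,4-dimethoxyphenyl in place of 3,4-dichlorophenyl on a saturated chain carbon bound to a nitrogen on an aromatic ring. Within the data shown here, no measured pair of compounds shows an exchange of this kind, so there is nothing to calibrate the step against, and the expectation rests on compound 3 alone. Given that compound 3 sits at 75900 nM, the change is expected to move the value only modestly, in no firm direction, and likely not beyond the usual scatter. The resulting step of a 1.2-fold lower number from compound 3 to compound 4 (0.07 log units; within the scatter) is thus expected to be small. For compound 4 the estimated value in this assay is 65000 nM, within a range from 25000 nM to 160000 nM.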

Compound 4, concentration lethal to 50% of the cells: 33900 nM
Compound 4: the middle estimate sits 1.9-fold (0.28 log units) above what was measured; the measured number falls inside the stated range.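

In this assay, the exchange at this place gives a 2.2-fold lower number from compound 3 to compound 4 (0.35 log units; beyond the scatter), the first change in a single place that can be read in the series shown. Although the step is modest, it shows that the read-out responds to what is carried on a saturated chain carbon bound to a nitrogen on an aromatic ring: with 3,4-dimethoxyphenyl there, less compound is tolerated than with 3,4-dichlorophenyl. Compound 1 and compound 2 could not show this, and the comparison therefore rests on a single pair of compounds: the limit of < 100000 nM in this assay, at which 2 of the 4 values shown sit.

The pair does not separate the loss of the two chlorine atoms from the arrival of the two oxygen-bearing methoxy groups, so it cannot say which of them accounts for the step. It also leaves open how this place would respond to an unsubstituted phenyl ring, a single methoxy group, or a phenyl ring carrying an amine or a carboxylic acid, and whether the same step would appear on the other linkage seen in compound 1.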